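The compounds below may be only part of what the source reports. "The series", "measured", "known", "first", "only" and "open" are said of these compounds alone.

Of the compounds shown here, three of a shared core have been measured in a functional assay on HeLa cells (Homo sapiens) for inhibition, read by MTT assay, with a stated time of 72 h; on this read-out higher numbers stand for weaker inhibition and lower numbers for stronger inhibition. Compound 1 `O=c1cc(Cn2cc(CCCCl)nn2)c2ccc(O)cc2o1` gives 49600 nM, compound 2 `O=c1cc(Cn2cc(CCc3ccccc3)nn2)c2ccc(O)cc2o1` gives 35100 nM, and compound 3 `O=c1cc(Cn2cc(CNS(=O)(=O)c3ccc(Cl)cc3)nn2)c2ccc(O)cc2o1` gives 58500 nM. Among the compounds with values here, the one single-point step among them, a 1.4-fold lower number from compound 1 to compound 2 (0.15 log units; within the scatter), stays within the scatter. Compound 3 sits at the upper end of the three numbers, but its gaps to compound 1 and to compound 2 are both within the scatter, so nothing separates the three.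

Compound 4 `O=c1cc(Cn2cc(CNS(=O)(=O)c3ccc([N+](=O)[O-])cc3)nn2)c2ccc(O)cc2o1` differs from compound 3 by nitro in place of chloro on an aromatic carbon. Within the data shown here, none of the measured steps touches this part of the structure: the only step that exists, from compound 1 to compound 2, alters the chain on the other side of the molecule and itself stays within the scatter. The whole set, from compound 1 through compound 3, spans a range that lies inside the scatter, so there is no ground in the numbers for a step in either direction in this assay. Compound 4 is therefore expected to give a number close to that of compound 3, with the step of a 1.1-fold lower number from compound 3 to compound 4 (0.03 log units; within the scatter) expected to stay within the scatter. The estimate for compound 4 is 55000 nM, with a range from 25000 nM to 120000 nM.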

Compound 4, half-maximal inhibitory concentration: > 100000 nM
Compound 4: only a limit was reported (the forecaster's own chance of this, stated with the estimate: 15%); middle value at least 1.8-fold (0.25 log units) from the limit.
By their numbers in this assay, from the lowest: compounds 2, 1 and 3 (each within the scatter of the next). At a limit, above all of these: compound 4.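

In this assay compound 4 gives > 100000 nM, which is a limit of the assay and not a number. This is the first change shown on the aromatic ring at the far end of the sulfonamide chain, and the step, an at least 1.7-fold higher number from compound 3 to compound 4 (0.23 log units; that floor lies within the scatter), points upward, but its floor does not clear the scatter, so the swap of 4-chlorophenyl to 4-nitrophenyl cannot be said to have made a real difference, even though the true size of the step may be larger than that floor. Compound 4 is also the only compound of the set without a measured number, so its distance from the others cannot be read, and the result rests on this one reading: the limit of > 100000 nM in this assay, at which 1 of the 4 values shown sits.

From the compounds shown here alone, it remains open whether an amine, a methoxy group or a carboxylic acid on the same aromatic carbon would give a number close to those of compound 1, compound 2 and compound 3 or would also end at a limit. Going by these compounds, it is equally open whether plain phenyl, with hydrogen in place of the chloro, would differ from 4-chlorophenyl in this assay, and whether nitro on the phenyl of compound 2 would behave as it does here.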